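The compounds below may be only part of what the source reports. "The series", "measured", "known", "first", "only" and "open" are said of these compounds alone.

Series notes. In a functional assay on HepG2 cells (Homo sapiens) for inhibition, read by MTT assay, with a stated time of 48 h (on this read-out lower numbers stand for stronger inhibition and higher numbers for weaker inhibition), compound 1 (`CCOC(=O)C1=C(N/C=N/c2nnc(S(N)(=O)=O)s2)Nc2[nH]nc(C)c2C1c1ccc(N(C)C)cc1`) gives 38100 nM, compound 2 (`CCOC(=O)C1=C(N/N=C(/C(=O)Br)c2ccc(Br)cc2)Nc2[nH]nc(C)c2C1c1ccc(N(C)C)cc1`) gives 65000 nM and compound 3 (`CCOC(=O)C1=C(N/C=N/c2ccccn2)Nc2[nH]nc(C)c2C1c1ccc(N(C)C)cc1`) gives 26200 nM. Compound 2 holds the highest of these three numbers, though a 1.7-fold higher number from compound 1 to compound 2 (0.23 log units; within the scatter) stays within the scatter, while a 2.5-fold lower number from compound 2 to compound 3 (0.39 log units; beyond the scatter) lies modestly beyond it. Compound 4 (`CCOC(=O)C1=C(N)Nc2[nH]nc(C)c2C1c1ccc(N(C)C)cc1`) departs from compound 2 by a hydrogen atom in place of a group of 12 heavy atoms (8 carbon, 1 nitrogen, 1 oxygen, 2 bromine; one six-membered aromatic ring of carbon only), on an amine nitrogen. Within the data shown here, no measured step removes the whole group, so the support is indirect. The other exchange, a 1.5-fold lower number from compound 1 to compound 3 (0.16 log units; within the scatter), is also within the scatter, and the largest step measured remains a 2.5-fold lower number from compound 2 to compound 3 (0.39 log units; beyond the scatter). The expected step in this assay is small, a 1.6-fold lower number from compound 2 to compound 4 (0.21 log units; within the scatter), toward a lower number but not beyond the scatter. Compound 4 is estimated at 40000 nM, with an expected range of 14000 nM to 110000 nM.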

Compound 4, half-maximal inhibitory concentration: 4240 nM
Compound 4: the middle estimate sits 9.4-fold (0.97 log units) above what was measured; measured number outside the range, below it.
By their numbers in this assay, from the lowest: compound 4; then compounds 3, 1 and 2 (each within the scatter of the next, the first and the last beyond it).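

With a hydrogen atom on the amine nitrogen, all three larger groups give way to a lower number: a 15-fold lower number from compound 2 to compound 4 (1.19 log units; beyond the scatter) and a 9.0-fold lower number from compound 1 to compound 4 (0.95 log units; beyond the scatter) and a 6.2-fold lower number from compound 3 to compound 4 (0.79 log units; beyond the scatter) all lie beyond the scatter. The largest exchange among the larger groups themselves is only a 2.5-fold lower number from compound 2 to compound 3 (0.39 log units; beyond the scatter) and so, at this position, removing the group altogether counts for more than any exchange shown. Nothing at hand explains this result.

From the compounds shown here alone, whether a methyl or acetyl group on this nitrogen keeps the lower number remains open. So does whether the unsubstituted amine itself is required.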